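Swapping butyl for phenyl: what to expect

The compounds below may be only part of what the source reports. "The series", "measured", "known", "first", "only" and "open" are said of these compounds alone.

Among the measured compounds shown here, in a functional assay on MOLT-4 cells (Homo sapiens) for antiproliferative activity, read by MTT assay, with a stated time of 3 days (on this read-out lower numbers stand for stronger inhibition and higher numbers for weaker inhibition), compound 1 `CCCCCCC#Cc1cn(C/C=C/CN2C(=O)c3ccccc3C2=O)c(=O)[nH]c1=O` gives 35000 nM and compound 2 `CCCCC#Cc1cn(C/C=C\CN2C(=O)c3ccccc3C2=O)c(=O)[nH]c1=O` gives 41000 nM as the only two numbers so far. These values lie within the usual scatter of repeated measurements, so compound 1 stands level with compound 2 and the two cannot be ranked.

Compound 3 `O=C1c2ccccc2C(=O)N1C/C=C/Cn1cc(C#CCCc2ccccc2)c(=O)[nH]c1=O` has not yet been measured. It differs from compound 1 by phenyl in place of butyl on a saturated chain carbon, two bonds along the chain from a triple-bonded carbon.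

For the measured compounds named here, no measured pair here shows what such a swap does in this assay so the expectation is a cautious one. Going by the values given here, a step no larger than the scatter is expected, leaning slightly towards stronger inhibition, although no measured pair supports that lean. The estimated change is a 1.4-fold lower number from compound 1 to compound 3 (0.15 log units; within the scatter) on this read-out. For compound 3 the expected value is 25000 nM with an estimated range from 9000 nM to 60000 nM around it.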

Compound 3, half-maximal inhibitory concentration: 39000 nM
For compound 3 the middle estimate is 1.6-fold (0.19 log units) below the measured one; low and high end bracket the measured number.
By their numbers in this assay, from the lowest: compounds 1, 3 and 2 (each within the scatter of the next).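

In this assay, putting phenyl in place of butyl on a saturated chain carbon, two bonds along the chain from a triple-bonded carbon, comes with a 1.1-fold higher number from compound 1 to compound 3 (0.05 log units; within the scatter), so the two compounds stand level and cannot be ranked. Among the compounds shown here, this is the first measured pair at this position, and it shows that the end of the chain can carry a six-membered aromatic ring of carbon only, with 6 heavy atoms instead of the 4 of butyl, without a step that rises above the scatter of the assay. No measurement among the data shown explains why the number stays level.

The compounds shown leave open whether this place accepts groups of another kind, such as an amine or a carboxylic acid at the end of the chain, since phenyl and butyl are both built of carbon alone. They also leave open whether a longer chain ending in phenyl, or a phenyl ring carrying a fluorine or a methoxy group, would give a number clearly apart from that of compound 1.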